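Chloro added to the phenyl of compound 3

The source may hold more compounds than are shown below. What is called first, only, known or untested is meant among the compounds shown, and "the series" means these compounds.

In a functional assay on Gurav cells (Homo sapiens) for inhibition, read by sulforhodamine B assay (on this read-out lower numbers stand for stronger inhibition of growth and higher numbers for weaker inhibition of growth), compound 3 (`Oc1cccc2[nH]c(-c3ccc(-c4ccc(-c5ccccc5)cc4)cc3)nc12`) gives 1110 nM, the lowest of three numbers, ahead of compound 2 (`COc1ccc(-c2ccc(-c3ccc(-c4nc5ccccc5[nH]4)cc3)cc2)cc1OC`) at 9230 nM and compound 1 (`c1ccc(-c2ccc(-c3ccc(-c4nc5ccccc5[nH]4)cc3)cc2)cc1`) at 100000 nM. Compound 4 (`Oc1cccc2[nH]c(-c3ccc(-c4ccc(-c5cccc(Cl)c5)cc4)cc3)nc12`) has chloro in place of hydrogen on an aromatic carbon, phenyl to 3-chlorophenyl: chloro in place of hydrogen on an aromatic carbon. Within the data shown here, the closest precedent is the large 11-fold lower number from compound 1 to compound 2 (1.03 log units; beyond the scatter), with 3,4-dimethoxyphenyl in place of phenyl. The large 90-fold lower number from compound 1 to compound 3 (1.95 log units; beyond the scatter), hydroxy in place of hydrogen, is already carried by compound 3. Among the measured compounds shown here, no chloro compound has been measured, and the dimethoxy step was measured without the hydroxy, so only a small move to a lower number is expected, possibly within the scatter. The expected move is a 1.6-fold lower number from compound 3 to compound 4 (0.20 log units; within the scatter). Compound 4 is estimated at 700 nM, within 250 nM to 2000 nM.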

Compound 4, concentration for 50% growth inhibition: 2310 nM
Compound 4: middle estimate off by 3.3-fold (0.52 log units), on the low side; the measured number lies above the stated range.
By their numbers in this assay, from the lowest: compound 3; then compound 4; then compound 2; then compound 1.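

In this assay chloro on the phenyl of the hydroxy-bearing core gives a 2.1-fold higher number from compound 3 to compound 4 (0.32 log units; beyond the scatter) and so adds nothing to the gain already carried by compound 3. This change at this position raises the number, whereas an 11-fold lower number from compound 1 to compound 2 (1.03 log units; beyond the scatter) on the same phenyl without the hydroxy lowered it. No measurement shown bears on the cause of this rise.

On these data alone, whether the rise belongs to chloro itself or to its place on the ring stays open. An amine or a carboxylic acid at the same carbon would test whether any group there lowers the number.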